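Swapping an open chain for piperazin-1-yl

This account rests on a few compounds, and the source may have more. Where it says the series, first, only, none or still open, it means among the compounds named here.

In a functional assay on HCT-116 cells (Homo sapiens) for cytotoxicity, read by fluorescence, with a stated time of 72 h (a higher number here means a weaker inhibitor, a lower number a stronger inhibitor), the measured values are:
compound 1 `CC(C)c1n[nH]c2c(NCc3ccc(-c4ccccn4)cc3)nc(S(C)(=O)=O)nc12` gives 1140 nM
compound 2 `CC(C)c1n[nH]c2c(NCc3ccc(-c4ccccn4)cc3)nc(NCCN)nc12` gives 227 nM
compound 3 `CC(C)c1n[nH]c2c(NCc3ccc(-c4ccccn4)cc3)nc(NCC(N)CO)nc12` gives 781 nM

Two steps place compound 3, namely a 1.5-fold lower number from compound 1 to compound 3 (0.16 log units; within the scatter) and a 3.4-fold higher number from compound 2 to compound 3 (0.54 log units; beyond the scatter), so it stands level with compound 1 and weaker than compound 2. Compound 4 `CC(C)c1n[nH]c2c(NCc3ccc(-c4ccccn4)cc3)nc(N3CCNCC3)nc12` carries piperazin-1-yl in place of that open chain, on the aromatic carbon between two ring nitrogen atoms (a group of 6 heavy atoms (4 carbon, 2 nitrogen; one six-membered non-aromatic ring with 2 hetero atoms) in place of a group of 6 heavy atoms (3 carbon, 2 nitrogen, 1 oxygen; no ring), on an aromatic carbon). Within the data shown here, no measured step makes this swap, and no ring has been tested at this place, so the guidance is indirect. Compound 4 has no hydroxymethyl, and neither does compound 2 (227 nM). The step that brought in (2-aminoethyl)amino (a 5.0-fold lower number from compound 1 to compound 2 (0.70 log units; beyond the scatter)) was modest, as was the one that added hydroxymethyl (a 3.4-fold higher number from compound 2 to compound 3 (0.54 log units; beyond the scatter)). The expected step in this assay is therefore modest and towards a lower number (a 2.0-fold lower number from compound 3 to compound 4 (0.29 log units; within the scatter)). Compound 4 is estimated at 400 nM, with an expected range of 130 nM to 1200 nM around it.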

Compound 4, half-maximal inhibitory concentration: 88 nM
For compound 4 the middle estimate is 4.5-fold (0.66 log units) above the measured one; measured number outside the range, below it.
By their numbers in this assay, from the lowest: compound 4; then compound 2; then compounds 3 and 1 (each within the scatter of the next).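

Piperazin-1-yl is the first ring seen on this aromatic carbon, between two ring nitrogen atoms, and in this assay it outdoes both open chains shown (a 2.6-fold lower number from compound 2 to compound 4 (0.41 log units; beyond the scatter); an 8.9-fold lower number from compound 3 to compound 4 (0.95 log units; beyond the scatter)). Against methylsulfonyl the change is the largest in the set (a 13-fold lower number from compound 1 to compound 4 (1.11 log units; beyond the scatter)), which makes compound 4 the strongest of the four and shows that a closed ring is accepted at this place, with no need for an open chain. The data shown give no measured explanation for this order.

As far as these compounds go, it remains open whether the ring itself matters or the second ring nitrogen does. Morpholine, with an oxygen in that spot, piperidine, with a carbon there, or 4-methylpiperazin-1-yl could help separate these, while a longer amine chain would test the open-chain side.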